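A few compounds are considered here, and "the series" means these few. Any claim that something is new, unique, unknown or untested is made for them only; others in the source may bear on it.

Measured in a functional assay on K562 cells (Homo sapiens), read by thymidine incorporation, with a stated time of 5 h; on this read-out higher numbers stand for weaker inhibition and lower numbers for stronger inhibition:
- compound 1 `O=C1Nc2c(ncn2Cc2ccccc2)C(C#Cc2ccccc2)N1Cc1ccccc1` gives 1.4 ug/mL
- compound 2 `O=C1Nc2c(ncn2Cc2ccccc2)C(C#CC2CC2)N1Cc1ccccc1` gives 1.6 ug/mL
- compound 3 `O=C1Nc2c(ncn2Cc2ccccc2)C(c2ccccc2)N1Cc1ccccc1` gives 5.1 ug/mL

Compound 3 stands at 5.1 ug/mL, the highest number of the three and so the weakest inhibition measured here. Compound 4 `CC1c2ncn(Cc3ccccc3)c2NC(=O)N1Cc1ccccc1` carries methyl in place of phenyl on a saturated ring carbon. Among the compounds with values here, two measured steps concern this same carbon: a 3.6-fold higher number from compound 1 to compound 3 (0.56 log units; beyond the scatter) and a 3.2-fold higher number from compound 2 to compound 3 (0.50 log units; beyond the scatter). Both went to a higher number when phenyl replaced an ethynyl-bearing group, but neither tests a group as small as methyl, so they are only a loose guide. A further modest rise is expected, and the estimated step is a 1.6-fold higher number from compound 3 to compound 4 (0.20 log units; within the scatter). For compound 4 the expected value is 8 ug/mL, within an estimated range of 3.5 ug/mL to 20 ug/mL.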

Compound 4, half-maximal inhibitory concentration: 2.5 ug/mL
Compound 4: middle estimate off by 3.2-fold (0.51 log units), on the high side; measured number outside the range, below it.
By their numbers in this assay, from the lowest: compounds 1, 2 and 4 (each within the scatter of the next); then compound 3.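

Replacing phenyl with methyl on this saturated ring carbon does not weaken inhibition in this assay, as the number falls (a 2.0-fold lower number from compound 3 to compound 4 (0.31 log units; beyond the scatter)). Methyl also sits level with both ethynyl-bearing groups (a 1.6-fold higher number from compound 2 to compound 4 (0.19 log units; within the scatter); a 1.8-fold higher number from compound 1 to compound 4 (0.25 log units; within the scatter)), so the number does not simply follow group size here: the smallest and largest groups match, while phenyl, intermediate in size, stands apart. No evidence here explains this difference. Still open, as far as these compounds go, is whether an ethyl group, a longer chain or an amine on this carbon would stay level with methyl or move towards phenyl.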